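A few compounds are considered here, and "the series" means these few. Any claim that something is new, unique, unknown or untested is made for them only; others in the source may bear on it.

Compound 1 `COc1cc(OC)cc(-c2ccc3cccnc3n2)c1` is tested in a functional assay on CHO cells for antagonist activity at metabotropic glutamate receptor 5 (Rattus norvegicus), read by calcium flux (a lower number here means a stronger inhibitor, a higher number a weaker inhibitor), where compound 1 gives 67 nM. Compound 2 `Cc1cccc(-c2cnc3cccnc3c2)c1` is built on a different core, and the difference between the two cores is not broken down here; in this assay compound 2 gives 15700 nM. Compound 3 `Cc1cc(C)cc(-c2cnc3cccnc3c2)c1` differs from compound 2 by the change (methyl in place of hydrogen on an aromatic carbon). For compound 3, this assay reports only a limit, > 30000 nM. The step from compound 2 to compound 3 reads an at least 1.9-fold higher number from compound 2 to compound 3 (0.28 log units; that floor lies within the scatter), and that reading rests on (the limit of > 30000 nM in this assay, at which 1 of the 3 values shown sits).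

Compound 4 `COc1cc(OC)cc(-c2ccc3ccc(C)nc3n2)c1` is not yet measured. It differs from compound 1 by methyl in place of hydrogen on an aromatic carbon. Going by the values given here, this is the same kind of change as the one from compound 2 to compound 3, but the place is not the same: there the methyl enters on a six-membered aromatic ring of carbon only, meta to a large group and meta to a methyl group, while here it enters on a six-membered aromatic ring with one nitrogen, part of a fused system of two rings, next to the ring nitrogen. A small weakening is expected, a 1.8-fold higher number from compound 1 to compound 4 (0.25 log units; within the scatter), because the measured step of an at least 1.9-fold higher number from compound 2 to compound 3 (0.28 log units; that floor lies within the scatter) leans that way while its floor still lies within the scatter. Compound 4 is therefore expected to give about 120 nM, estimated to fall between 30 nM and 600 nM.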

Compound 4, half-maximal inhibitory concentration: 51.7 nM
For compound 4 the middle estimate is 2.3-fold (0.37 log units) above the measured one, within the range that was stated.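

On the core of compound 1, the methyl costs nothing that can be detected in this assay: the step is a 1.3-fold lower number from compound 1 to compound 4 (0.11 log units; within the scatter). The same change has now been seen on two cores, but this does not show whether it acts alike on both: the same change on two cores in this assay, an at least 1.9-fold higher number (0.28 log units; that floor lies within the scatter) from compound 2 to compound 3 and a 1.3-fold lower number (0.11 log units; within the scatter) from compound 1 to compound 4; the limit leaves it open whether they differ. Compound 3 gives only a limit, so the earlier step has a floor and no true size, and the comparison cannot show that the change carries over from one core to the other: the limit of > 30000 nM in this assay, at which 1 of the 4 values shown sits.

The compounds shown leave open what a group other than methyl would do on this same aromatic carbon, for instance an amine or a longer chain such as ethyl. They also leave open whether a methyl on the core of compound 2 would read the same if it entered on a six-membered aromatic ring with 1 nitrogen, next to the ring nitrogen.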